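Shortening the ether chain of compound 2 and dropping its nitrile

The source may report more compounds than this note shows. Statements on the series, on what has been measured and on what is new or still open speak of the compounds shown alone.

Measured so far:
compound 1, `CC(=O)c1cc(C=O)c(OCCCCC#N)cc1O` — 3%
compound 2, `C=CCc1cc(C(C)=O)c(O)cc1OCCCCCCCC#N` — 52%
compound 3, `CCc1cc(C(C)=O)c(O)cc1OCCCCCC(C)(C)C(=O)O` — 73%

Of the compounds shown here, three have been tested in an assay on isolated protein for binding affinity to leukotriene B4 receptor 1 (Homo sapiens), tested at 1 uM; on this read-out higher numbers stand for more inhibition at the one concentration tested (going by the name of the read-out) and lower numbers for less inhibition. Compound 1 gives 3%, compound 2 gives 52% and compound 3 gives 73%. Compound 2 stands second of the three: compound 3 lies above it by a margin beyond the usual scatter, and compound 1 lies below it by a still larger margin, also beyond the scatter. No pair among these three differs in a single place, so none of the gaps can be tied to one structural change.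

Compound 4, `C=CCCCCOc1cc(O)c(C(C)=O)cc1CC=C`, has not yet been measured. Set against compound 2 it differs in one place: vinyl in place of 3-cyanopropyl on a saturated chain carbon, four bonds along the chain from an oxygen on an aromatic ring. Among the compounds with values here, since the measured compounds offer no single-point step to go by, the direction and size of this one are open. The hexenyl chain that results keeps the same core as compound 2 but ends without any polar group, and of the measured compounds only compound 1, with its much shorter cyano chain, comes close to that pattern. Compound 4 is therefore expected to fall somewhat below compound 2 in this assay, by a step of a number 17 percentage points lower from compound 2 to compound 4 (beyond the scatter), which is taken as beyond the scatter. The estimate for compound 4 is 35%, with a range from 10% to 60%.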

Compound 4, a percentage reported as inhibition, at one concentration (the size of the read-out at that concentration, not a potency): 27%
Compound 4: the middle estimate sits 8 percentage points above what was measured, within the range that was stated.
By their numbers in this assay, from the lowest: compound 1; then compound 4; then compound 2; then compound 3.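

Replacing 3-cyanopropyl with vinyl on a saturated chain carbon, four bonds along the chain from an oxygen on an aromatic ring, gives the first single-place comparison among these compounds: in this assay it appears as a number 25 percentage points lower from compound 2 to compound 4 (beyond the scatter), so this end of the ether chain is not indifferent to the change, although compound 4 still registers inhibition at the one concentration tested. The swap shortens the chain and removes the nitrile at once, so this single step cannot show which of the two accounts for the lower number. No available measurement bears on why the read-out moves.

The compounds shown leave open whether a nitrile on a shorter chain, or a plain alkyl chain matching the length of the one in compound 2, would stay nearer to compound 2 or to compound 4. They also leave open how a carboxylic acid or an amine at the end of this same chain would read on the core shared by compound 2 and compound 4.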